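Cyanosulfanyl for Bromo on a Cytotoxicity-Silent Core

The compounds below may be only part of what the source reports. "The series", "measured", "known", "first", "only" and "open" are said of these compounds alone.

Compound 1, `Cc1ccc(-c2nc3sc(Cc4ccc(Cl)cc4)nn3c2Br)cc1`, gives in a functional assay on HeLa cells (Homo sapiens) for cytotoxicity, with a stated time of 72 h (a higher number here means a weaker inhibitor, a lower number a stronger inhibitor), only the assay limit > 250000 nM. Compound 2, `O=[N+]([O-])c1ccc(-c2nc3sc(Cc4ccc(Cl)cc4)nn3c2Br)cc1`, gives in this assay only the assay limit > 250000 nM.

So compound 2 stands at the limit of the numbers shown, with no measured inhibitory concentration of its own. Among the compounds with values here, the one measured step, a step that the two limits leave unreadable from compound 1 to compound 2, cannot be sized because the limit of > 250000 nM in this assay, at which 2 of the 2 values shown sit, holds both values shown. Compound 3, `N#CSc1c(-c2ccc([N+](=O)[O-])cc2)nc2sc(Cc3ccc(Cl)cc3)nn12`, differs from compound 2 by cyanosulfanyl in place of bromo on an aromatic carbon. Within the data shown here, no measured step involves this change, so nothing among the measured compounds speaks for a shift in either direction. With both measured compounds sitting at the limit, compound 3 is expected to sit there too, an estimated 250000 nM within 60000 nM to 1000000 nM. That estimate means an expected step of a number no higher from compound 2 to compound 3 (the limit leaves the size open), no change beyond the scatter.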

Compound 3, half-maximal inhibitory concentration: 16000 nM
Compound 3: the middle estimate sits 16-fold (1.19 log units) above what was measured; the measured number lies below the stated range.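

Cyanosulfanyl in place of bromo on this aromatic carbon gives an at least 15-fold lower number from compound 2 to compound 3 (1.19 log units; beyond the scatter) in this assay. Within the data shown here, this position therefore matters in a way the earlier compounds could not show: compound 1 and compound 2 differ only on the other aromatic ring and gave no readable step, whereas this change brings the first measured inhibitory concentration. The step is a minimum, and the true gap may be larger, for compound 2 has only a limit and no number of its own: the limit of > 250000 nM in this assay, at which 2 of the 3 values shown sit.

How a plain nitrile or a methylsulfanyl group would compare at this place stays open, so the compounds shown do not tell whether the sulfur, the nitrile or the whole group matters. Also open, as far as these compounds go, is whether cyanosulfanyl would give a similar step with the methyl of compound 1 in place of the nitro.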